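A few compounds are considered here, and "the series" means these few. Any claim that something is new, unique, unknown or untested is made for them only; others in the source may bear on it.

In an assay on isolated protein for displacement of a labelled ligand from 5-hydroxytryptamine receptor 6 (Homo sapiens) (a higher number here means a weaker inhibitor, a lower number a stronger inhibitor), compound 2 `NC(=O)CNC[C@@H]1CCCc2cc(S(=O)(=O)c3cccc(F)c3)ccc21` gives 0.1 nM, the lowest of the two numbers recorded so far, while compound 1 `CS(=O)(=O)c1cccc(S(=O)(=O)c2ccc3c(c2)CCC[C@H]3CN)c1` gives 3.98 nM, a gap well beyond the scatter. Compound 3 `O=C(CO)NC[C@@H]1CCCc2cc(S(=O)(=O)c3cccc(F)c3)ccc21` is not yet measured; it differs from compound 2 in one place: (hydroxymethyl)carbonyl in place of carbamoylmethyl on an amine nitrogen. Among the compounds with values here, with no step of this kind measured, the expected change is a 300-fold higher number from compound 2 to compound 3 (2.48 log units; beyond the scatter), an estimated move toward a higher number that should exceed the scatter. On that basis compound 3 is estimated at 30 nM, with a range of 3 nM to 300 nM.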

Compound 3, inhibition constant: 0.1 nM
Estimate against measurement, compound 3: 300-fold (2.48 log units) above, and the stated range ends above it.
By their numbers in this assay, from the lowest: compounds 2 and 3 (each within the scatter of the next); then compound 1.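

In this assay, the first step read at this position, (hydroxymethyl)carbonyl in place of carbamoylmethyl on an amine nitrogen, gives no change at the digits printed from compound 2 to compound 3 (within the scatter). The position therefore accepts both groups, which have the same heavy-atom count but differ in one atom and in hydrogen-bond acceptor count. Nothing available bears on why the two groups read alike.

Still open, going by these compounds, is how a carboxylic acid, a longer chain or a plain acetyl group on the same nitrogen would read. Compounds 2 and 3 alone cannot show how far this tolerance extends.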